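Propyl to hexyl on the core of compound 1

A few compounds are considered here, and "the series" means these few. Any claim that something is new, unique, unknown or untested is made for them only; others in the source may bear on it.

In a functional assay on NCI-H358 cells (Homo sapiens) for cytotoxicity, read by sulforhodamine B assay (on this read-out lower numbers stand for an effect already at smaller amounts and higher numbers for an effect only at larger amounts of compound), compound 1 (`CCCCCCCCCCCCC/C=C/[C@@H](O)[C@H](CO)n1cc(CCC)nn1`) gives 15700 nM and compound 2 (`CCCCCCCCCCCCCC[C@@H](O)[C@@H](O)[C@H](CO)n1cc(CCCC)nn1`) gives 12900 nM so the two values lie within the scatter of each other. Compound 3 (`CCCCCCCCCCCCC/C=C/[C@@H](O)[C@H](CO)n1cc(CCCCCCCCCCCCCCCCCCCCCCCC)nn1`) returns > 50000 nM which is a limit of the assay and not a number. Compound 4 (`CCCCCCCCCCCCC/C=C/[C@@H](O)[C@H](CO)n1cc(CCCCCC)nn1`) differs from compound 1 by propyl in place of hydrogen on a saturated chain carbon, three bonds along the chain from an aromatic carbon and the same difference reads propyl to hexyl. For the measured compounds named here, no measured pair isolates this change, so the expectation starts from compound 1 at 15700 nM and points to a small move toward a higher number. The expected step, estimated as a 1.4-fold higher number from compound 1 to compound 4 (0.15 log units; within the scatter), stays within the scatter. Compound 4 is estimated at 22000 nM with an expected range from 9000 nM to 50000 nM for now.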

Compound 4, half-maximal effective concentration: 12800 nM
For compound 4 the middle estimate is 1.7-fold (0.24 log units) above the measured one, and the stated range covers the measured number.
By their numbers in this assay, from the lowest: compounds 4, 2 and 1 (each within the scatter of the next). At a limit, above all of these: compound 3.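

Propyl in place of hydrogen on a saturated chain carbon, three bonds along the chain from an aromatic carbon, gives a 1.2-fold lower number from compound 1 to compound 4 (0.09 log units; within the scatter) in this assay, so this first readable step at the position shows no shift beyond the scatter. Compound 3 stands at a limit of the assay, > 50000 nM. Nothing shown gives a cause for the size of this step.

Chains longer than hexyl but shorter than the one on compound 3 remain open. Also open, as far as these compounds go, is whether an amine or a carboxylic acid in place of the hexyl group would move the number beyond the scatter.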